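The source may report more compounds than this note shows. Statements on the series, on what has been measured and on what is new or still open speak of the compounds shown alone.

Measured compounds:
- compound 1, `O=C(/C=C/c1ccc([N+](=O)[O-])o1)c1ccc(-c2ccccc2)cc1` — 50400 nM
- compound 2, `CSc1ccc(C(=O)/C=C/c2ccco2)cc1` — > 50000 nM
- compound 3, `COc1ccc(/C=C/C(=O)c2cccc(Br)c2)cc1` — > 50000 nM

These three compounds were tested in an ADME assay on THP-1 cells (Homo sapiens) for cytotoxicity, read by resazurin assay, with a stated time of 72 h; on this read-out lower numbers stand for higher toxicity in this test and higher numbers for lower toxicity in this test. Compound 1 is the only one of the three that returns an actual number, at 50400 nM. For compound 2 the result of > 50000 nM is a limit of the test, not a number. For compound 3 the result of > 50000 nM is likewise a limit. Two of the three results therefore sit at the limit of > 50000 nM in this assay, at which 2 of the 3 values shown sit, and compound 1 stands close to that same edge, so on the evidence available all three look weakly toxic to these cells in this assay.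

Compound 4, `O=C(/C=C/c1ccc([N+](=O)[O-])o1)c1ccc(N2CCCC2)cc1`, has not yet been tested. It differs from compound 1 in one place: pyrrolidin-1-yl in place of phenyl on an aromatic carbon. Within the data shown here, no measured pair of compounds in this set differs by a single change, so there is no measured step to lean on for the size of the effect. Given how closely compound 1 sits to the limit, the step from compound 1 to compound 4 in this assay is expected to be small, a 1.1-fold lower number from compound 1 to compound 4 (0.05 log units; within the scatter), with no clear direction beyond the scatter. Compound 4 is therefore estimated to give about 45000 nM in this assay, within a range of 15000 nM to 120000 nM.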

Compound 4, half-maximal cytotoxic concentration: > 50000 nM
Compound 4: no number, only a limit (the forecaster's own chance of this, stated with the estimate: 50%); middle value at least 1.1-fold (0.04 log units) away from the limit.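

In this assay compound 4 gives > 50000 nM, which is a limit of the test and not a number. The step between compound 1 and compound 4 therefore cannot be read. The compounds shown leave open how large the effect of pyrrolidin-1-yl in place of phenyl is, and in which direction it runs: the limit of > 50000 nM in this assay, at which 3 of the 4 values shown sit.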